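Ring substituent changes and cytotoxicity in this series

The source may report more compounds than this note shows. Statements on the series, on what has been measured and on what is new or still open speak of the compounds shown alone.

Compound 1 `O=c1[nH]c(=O)n(Cc2ccccc2)cc1Nc1ccccc1` in an ADME assay on CEM-SS cells (Homo sapiens) for cytotoxicity, read by XTT assay (on this read-out higher numbers stand for lower toxicity in this test and lower numbers for higher toxicity in this test), gives > 100000 nM, which is a limit of the assay and not a number. Compound 2 `Cc1cccc(Cn2cc(Nc3ccccc3)c(=O)[nH]c2=O)c1` gives > 200000 nM in this assay, again a limit. The step that the two limits leave unreadable from compound 1 to compound 2 is unreadable, since both values sit at limits, as the limit of > 100000 nM in this assay, at which 1 of the 3 values shown sits, and the limit of > 200000 nM in this assay, at which 1 of the 3 values shown sits, show. Compound 3 `O=c1[nH]c(=O)n(Cc2cccc(Cl)c2)cc1Nc1ccccc1` has no result in this assay; its entry reads "not determined" (no result reported). Compound 3 therefore stands nowhere on the numbers shown. Compound 4 `O=c1[nH]c(=O)n(Cc2cccc(Oc3ccccc3)c2)cc1Nc1ccccc1` differs from compound 3 by phenoxy in place of chloro on an aromatic carbon. Going by the values given here, no measured step bears on this change, and the one step available is unreadable. Both measured compounds sit at limits, the limit of > 100000 nM in this assay, at which 1 of the 3 values shown sits, and (the limit of > 200000 nM in this assay, at which 1 of the 3 values shown sits), so a limit is the likeliest outcome here too. Compound 4 is expected at about 150000 nM, with a range of 40000 nM to 500000 nM.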

Compound 4, half-maximal cytotoxic concentration: > 100000 nM
Compound 4: only a limit was reported (the forecaster's own chance of this, stated with the estimate: 75%); the middle value lies beyond the limit too.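

In this assay compound 4 gives > 100000 nM, a limit and not a number, so its steps from compound 1 and compound 2 cannot be read. The compounds shown leave open whether any of these ring substituents changes cytotoxicity at all.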